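From benzyl to isobutyl on the shared core

The source may hold more compounds than are shown below. What is called first, only, known or untested is meant among the compounds shown, and "the series" means these compounds.

Going by the values given here, compound 2 `Cc1ccc(-c2cnc(N(Cc3ccccc3)Cc3ccc(C(=O)NO)cc3)s2)cc1` gives 4410 nM in a functional assay on A549 cells (Homo sapiens) for antiproliferative activity, read by MTT assay, with a stated time of 48 h (on this read-out higher numbers stand for weaker inhibition of growth and lower numbers for stronger inhibition of growth), and so holds the lower of the two numbers so far, while compound 1 `CCCCCN(Cc1ccc(C(=O)NO)cc1)c1ncc(-c2ccc(C)cc2)s1` gives 9140 nM there. The change to compound 3 `Cc1ccc(-c2cnc(N(Cc3ccc(C(=O)NO)cc3)CC(C)C)s2)cc1` is isopropyl in place of phenyl on a saturated chain carbon bound to a nitrogen on an aromatic ring and reads isopropyl in place of phenyl on a saturated chain carbon bound to a nitrogen on an aromatic ring. Among the compounds with values here, the one measured step bearing on it is a 2.1-fold lower number from compound 1 to compound 2 (0.32 log units; beyond the scatter) for phenyl in place of butyl, so losing phenyl should give a rise of similar modest size in this assay rather than none. The estimated step is a 2.0-fold higher number from compound 2 to compound 3 (0.31 log units; beyond the scatter) in that direction. Compound 3 is estimated at 9000 nM within 4500 nM to 18000 nM as the expected range.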

Compound 3, concentration for 50% growth inhibition: 20400 nM
For compound 3 the middle estimate is 2.3-fold (0.36 log units) below the measured one; measured number outside the range, above it.
By their numbers in this assay, from the lowest: compound 2; then compound 1; then compound 3.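

Isopropyl in place of phenyl gives a 4.6-fold higher number from compound 2 to compound 3 (0.67 log units; beyond the scatter) in this assay, a larger change than the one phenyl brought over butyl. Isopropyl in place of butyl also gives a 2.2-fold higher number from compound 1 to compound 3 (0.35 log units; beyond the scatter) here, so this place separates two saturated groups from each other and not only phenyl from a saturated group. Nothing measured here gives a cause for these shifts. Open, as far as these compounds go, is what an amine or a carboxylic acid at this place would do, and whether a substituted phenyl would give a lower number than compound 2 does.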